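A bromophenyl swap: compound 2 to compound 4

The source may hold more compounds than are shown below. What is called first, only, known or untested is meant among the compounds shown, and "the series" means these compounds.

Measured so far in a functional assay on PC-3 cells (Homo sapiens) for cytotoxicity, read by MTT assay, with a stated time of 72 h (on this read-out higher numbers stand for weaker inhibition and lower numbers for stronger inhibition), as follows:
compound 1 `CNC(=O)c1cc(Oc2ccc(C(=O)/C=C/c3ccco3)cc2)ccn1` gives "not determined" (no result reported)
compound 2 `CNC(=O)c1cc(Oc2ccc(C(=O)/C=C/c3cccc(Br)c3)cc2)ccn1` gives 3400 nM
compound 3 `CNC(=O)c1cc(Oc2ccc(C(=O)/C=C/c3ccc(OC)c(OC)c3OC)cc2)ccn1` gives "not determined" (no result reported)

For the measured compounds named here, compound 2 carries the only number in this set, so it cannot be ranked against compound 1 or compound 3. Compound 4 `CNC(=O)c1cc(Oc2ccc(C(=O)/C=C/c3ccc(Br)cc3)cc2)ccn1` is still unmeasured. Against compound 2 it has the same atoms, joined differently (4-bromophenyl in place of 3-bromophenyl on a double-bonded chain carbon bound to a double-bonded chain carbon), with 4-bromophenyl in place of 3-bromophenyl. Going by the values given here, no measured pair shows the size of such a change. An expected step of a 1.1-fold lower number from compound 2 to compound 4 (0.05 log units; within the scatter) stays within the usual scatter, in no favoured direction. This expectation rests on compound 2 alone at 3400 nM in the absence of other numbers. Compound 4 is estimated at 3000 nM with an expected range of 1000 nM to 9000 nM in this assay when measured.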

Compound 4, half-maximal inhibitory concentration: 18500 nM
Compound 4: middle estimate off by 6.2-fold (0.79 log units), on the low side; measured number above the stated range.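

In this assay, 4-bromophenyl in place of 3-bromophenyl on a double-bonded chain carbon bound to a double-bonded chain carbon gives a 5.4-fold higher number from compound 2 to compound 4 (0.74 log units; beyond the scatter). This first measured pair shows that this read-out can separate two groups with the same atoms, joined differently. Nothing measured here bears on why they differ.

Steps to compound 1 and compound 3 cannot be read, as neither has a number. Still open, as far as these compounds go, is how an amine or a carboxylic acid in place of the bromine would read.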